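Acid-to-taurine-amide step in a bile acid receptor agonist series

The source may report more compounds than this note shows. Statements on the series, on what has been measured and on what is new or still open speak of the compounds shown alone.

Compound 3 `CN(Cc1ccc(C(=O)O)cc1)c1ccc(OCc2c(-c3c(Cl)cccc3Cl)noc2C2CC2)nc1C(F)(F)F` sits second highest of the three numbers measured in a functional assay on HEK293 cells for agonist activity at Bile acid receptor (Homo sapiens) (on this read-out lower numbers stand for an effect already at smaller amounts and higher numbers for an effect only at larger amounts of compound), at 30 nM. Going by the values given here, its nearest neighbour is compound 1 `CN(Cc1cccc(C(=O)O)c1)c1ccc(OCc2c(-c3c(Cl)cccc3Cl)noc2C2CC2)nc1C(F)(F)F`, which in this assay gives 9 nM; the step of a 3.3-fold higher number from compound 1 to compound 3 (0.52 log units; beyond the scatter) is the only single-point change measured so far. Compound 2 `CC(C)c1onc(-c2c(Cl)cccc2Cl)c1COc1ccc(N(C)Cc2cccc(C(=O)NS(C)(=O)=O)c2)c(C(F)(F)F)n1`, the furthest value, gives 279 nM in this assay; it differs from compound 1 in more than one place, so only its two values can be compared.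

Compound 4 `CN(Cc1ccc(C(=O)NCCS(=O)(=O)O)cc1)c1ccc(OCc2c(-c3c(Cl)cccc3Cl)noc2C2CC2)nc1C(F)(F)F` is obtained from compound 3 by (2-sulfoethyl)amino in place of hydroxy on a carbonyl carbon. Among the compounds with values here, no measured step covers this change. Compound 2 carries an acid replaced by an acyl sulfonamide and is the weakest value seen, but its additional difference at the isoxazole substituent keeps that comparison indirect. The expectation is therefore a weakening beyond the scatter, of moderate size, a 4.0-fold higher number from compound 3 to compound 4 (0.60 log units; beyond the scatter), with wide uncertainty. Compound 4 is estimated at 120 nM in this assay, in the range 30 nM to 500 nM.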

Compound 4, half-maximal effective concentration: 1420 nM
Estimate against measurement, compound 4: 12-fold (1.07 log units) below, and the stated range ends below it.
By their numbers in this assay, from the lowest: compound 1; then compound 3; then compound 2; then compound 4.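

The carbonyl carbon bound to the aromatic carbon proves far less forgiving than the earlier change in carboxyphenyl placement: carboxy to (2-sulfoethyl)carbamoyl gives a large step in this assay (a 47-fold higher number from compound 3 to compound 4 (1.68 log units; beyond the scatter)), against the modest step (a 3.3-fold higher number from compound 1 to compound 3 (0.52 log units; beyond the scatter)). At this position the longer (2-sulfoethyl)carbamoyl chain is therefore no like-for-like replacement for carboxy, although compound 4 still returns a finite value in this read-out. Nothing at hand gives a reason for the size of this step.

A carboxymethylcarbamoyl group or a plain methylcarbamoyl group on this carbonyl carbon would help separate the contribution of the amide link from that of the sulfo end. Also open, going by these compounds, is whether (2-sulfoethyl)carbamoyl on the 3-carboxyphenyl arrangement of compound 1 would bring a step of similar size.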